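Replacing a Methoxy Group with Iodine at the Sulfonamide Nitrogen

The source may report more compounds than this note shows. Statements on the series, on what has been measured and on what is new or still open speak of the compounds shown alone.

Compound 3 `COc1ccccc1NS(=O)(=O)c1ccc(N2CCNC2=O)cc1` gives 300 nM in a functional assay on M21 cells (Homo sapiens) for antiproliferative activity, read by sulforhodamine B assay, with a stated time of 48 h (on this read-out lower numbers stand for stronger inhibition and higher numbers for weaker inhibition), the higher of the two numbers measured there. Its nearest neighbour is compound 1 `O=C1NCCN1c1ccc(S(=O)(=O)Nc2ccc(F)c(F)c2)cc1`, which in this assay gives 220 nM; the step of a 1.4-fold higher number from compound 1 to compound 3 (0.13 log units; within the scatter) lies within the scatter, so the two compounds cannot be ordered. Compound 2 `CC(C)Cc1ccc(NS(=O)(=O)c2ccc(N3CCNC3=O)cc2)cc1` reaches only a limit of this assay, > 1000 nM. Compound 4 `O=C1NCCN1c1ccc(S(=O)(=O)Nc2ccc(I)cc2)cc1` differs from compound 3 in one place: 4-iodophenyl in place of 2-methoxyphenyl on a sulfonamide nitrogen. Among the compounds with values here, no measured step involves a 4-iodophenyl group, and the single measured step at this position stayed within the scatter, so no change beyond the scatter is expected for compound 4 in this assay. Compound 4 is therefore estimated at 300 nM, between 100 nM and 1000 nM, which means a step of no change at the digits printed from compound 3 to compound 4 (within the scatter).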

Compound 4, half-maximal inhibitory concentration: 260 nM
Beside the measured number, compound 4's estimate is 1.2-fold (0.06 log units) above it; the measured number falls inside the stated range.
By their numbers in this assay, from the lowest: compounds 1, 4 and 3 (each within the scatter of the next). At a limit, above all of these: compound 2.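

Neither a 1.2-fold lower number from compound 3 to compound 4 (0.06 log units; within the scatter) nor a 1.2-fold higher number from compound 1 to compound 4 (0.07 log units; within the scatter) separates the groups on the sulfonamide nitrogen, so 4-iodophenyl, 2-methoxyphenyl and 3,4-difluorophenyl cannot be ordered in this assay. Within the data shown here, the position is not indifferent to every change, however: an at least 3.8-fold lower number from compound 2 to compound 4 (0.58 log units; beyond the scatter) is the first step here beyond the scatter, with iodo in place of isobutyl on an aromatic carbon. Compound 2 gives a limit, not a number: the limit of > 1000 nM in this assay, at which 1 of the 4 values shown sits. The compounds shown leave open how an amine or a carboxylic acid on this aromatic ring would read in this assay.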